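Swapping sec-butyl for cyclohexyl on the sulfur

This account rests on a few compounds, and the source may have more. Where it says the series, first, only, none or still open, it means among the compounds named here.

Four compounds share a core in which a sulfur carries a small hydrocarbon group, and they were compared in a functional assay on MT4 cells (Homo sapiens) for cytotoxicity; a lower number here means that less compound is tolerated, a higher number that more compound is tolerated. Compound 1 is `CCC(C)Sc1nc(O)cc(C(CC)c2ccccc2)n1` and compound 2 is `CCC(c1ccccc1)c1cc(O)nc(SC2CCCCC2)n1`. The two differ only by cyclohexyl in place of sec-butyl on a sulfur. In this assay compound 2 gives 51000 nM. Compound 1 reaches no number in this assay, only the limit > 200000 nM. The step is an at least 3.9-fold lower number from compound 1 to compound 2 (0.59 log units; beyond the scatter), so the cyclohexyl compound is tolerated less well.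

Compound 3 is `CCC(C)Sc1nc(O)cc(C(C)c2c(F)cccc2F)n1`. It also reaches only the limit of this assay, giving > 200000 nM. How the core of compound 3 differs from the core of compound 1 is not broken down here. Two of the three measured values sit at the same place, which is the limit of > 200000 nM in this assay, at which 2 of the 3 values shown sit.

Compound 4 is `CC(c1cc(O)nc(SC2CCCCC2)n1)c1c(F)cccc1F` and has not been measured. From compound 3 it differs by cyclohexyl in place of sec-butyl on a sulfur, the same change, at the same kind of sulfur, that separates compound 1 from compound 2. Since compound 3 sits at the limit, the starting point is uncertain, and the step from compound 1 to compound 2 rests on a single pair. Still, the expectation for the step is an at least 2.5-fold lower number from compound 3 to compound 4 (0.39 log units; beyond the scatter), because an at least 3.9-fold lower number from compound 1 to compound 2 (0.59 log units; beyond the scatter). Compound 4 is therefore estimated at 80000 nM in this assay, with a likely range from 30000 nM to 200000 nM, and with a fair chance that only a limit is reported.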

Compound 4, half-maximal cytotoxic concentration: > 200000 nM
Compound 4 was reported as a limit (the forecaster's own chance of this, stated with the estimate: 35%); middle value at least 2.5-fold (0.39 log units) away from the limit.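

In this assay compound 4 gives > 200000 nM, which is a limit and not a number. Among these compounds, compound 3 also stands at a limit, so no step from compound 3 to compound 4 can be read. The compounds shown leave open whether cyclohexyl in place of sec-butyl on a sulfur lowers the number on the core of compound 3 as it does on the core of compound 1, with most values now at one place: the limit of > 200000 nM in this assay, at which 3 of the 4 values shown sit.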